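The source may hold more compounds than are shown below. What is called first, only, known or untested is meant among the compounds shown, and "the series" means these compounds.

Series notes, read-out a physicochemical assay for solubility, read by LC-MS, in phosphate buffer, with a stated time of 24 h, at pH 6.8; on this read-out higher numbers stand for higher solubility and lower numbers for lower solubility. Compound 1 `C[C@@H](c1ccc(NC(=O)N2CC(c3cccnc3)C2)cc1)N1Cc2ccccc2C1=O` gives 130000 nM. Compound 3 `C[C@@H](c1ccc(NC(=O)N2CC(c3ccc(N)nc3)C2)cc1)N1Cc2ccccc2C1=O` gives 220000 nM, and the step of a 1.7-fold higher number from compound 1 to compound 3 (0.23 log units; within the scatter) keeps it within the scatter of compound 1. Compound 2 `C[C@H](NC(=O)[C@@H]1CCCN1C)c1ccc(NC(=O)N2CC(c3cccnc3)C2)cc1` reads > 1000000 nM, which is a limit of this assay and not a number. Going by the values given here, compound 3 therefore has only one numerical neighbour, and the third value shown gives no exact position.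

Next is compound 4 `C[C@H](NC(=O)C1CCOCC1)c1ccc(NC(=O)N2CC(c3ccc(N)nc3)C2)cc1`, which differs from compound 3 as follows: a group of 9 heavy atoms (6 carbon, 1 nitrogen, 2 oxygen; one six-membered non-aromatic ring with 1 hetero atom) in place of a group of 10 heavy atoms (8 carbon, 1 nitrogen, 1 oxygen; one five-membered non-aromatic ring with 1 hetero atom, one six-membered aromatic ring of carbon only), on a saturated chain carbon bound to an aromatic carbon and a saturated chain carbon. The entering group is ((oxan-4-yl)carbonyl)amino, on a saturated chain carbon bound to an aromatic carbon and a saturated chain carbon.

Among the compounds with values here, two measured steps bear on this. The closer one is an at least 7.6-fold higher number from compound 1 to compound 2 (0.88 log units; beyond the scatter), where the same group leaves from the same place, although a different group enters. The other is a 1.7-fold higher number from compound 1 to compound 3 (0.23 log units; within the scatter), which suggests that the amino substituent need not shift the comparison beyond the scatter. One precedent with a different entering group supports the direction better than the size, so a higher number of moderate size is expected in this assay. The expected change is a 2.3-fold higher number from compound 3 to compound 4 (0.36 log units; beyond the scatter). For compound 4 the estimated value is 500000 nM, with an expected range of 200000 nM to 1000000 nM.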

Compound 4, solubility: 310000 nM
Compound 4: the middle estimate sits 1.6-fold (0.21 log units) above what was measured; measured number inside the range.
By their numbers in this assay, from the lowest: compounds 1, 3 and 4 (each within the scatter of the next, the first and the last beyond it). At a limit, above all of these: compound 2.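

In this assay, ((oxan-4-yl)carbonyl)amino on a saturated chain carbon bound to an aromatic carbon and a saturated chain carbon gives a 1.4-fold higher number from compound 3 to compound 4 (0.15 log units; within the scatter), so this exchange, made on the core of compound 3, does not separate from the scatter. Going by these compounds alone, the only earlier change at this place, with a different entering group and on the core without the amino substituent, was an at least 7.6-fold higher number from compound 1 to compound 2 (0.88 log units; beyond the scatter), so the new step shows that replacing the same leaving group does not by itself move the read-out beyond the scatter. Compound 2 reads a limit and not a number, and the size of that earlier step stays undefined because of it: the limit of > 1000000 nM in this assay, at which 1 of the 4 values shown sits.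

The compounds shown leave open how ((oxan-4-yl)carbonyl)amino reads on the core of compound 1 and how the entering group of compound 2 reads on the core of compound 3, so the contributions of the entering group and the amino substituent cannot yet be told apart. Also open, on these data alone, is how a carboxylic acid or a dimethylamino group reads at this place in this assay.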